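Toward a Pyridinyl Analogue in the Brine Shrimp Test

A few compounds are considered here, and "the series" means these few. Any claim that something is new, unique, unknown or untested is made for them only; others in the source may bear on it.

Compound 1, `COc1ccc(/C=C/C(=O)c2ccccc2NC(=O)NS(=O)(=O)c2ccc(C)cc2)c(OC)c1`: 16 ug/mL in an ADME assay on the whole organism for cytotoxicity, with Artemia salina as the target, with a stated time of 24 h; a lower number here means that less compound is needed, a higher number that more compound is needed for the effect
Compound 2, `Cc1ccc(S(=O)(=O)NC(=O)Nc2ccccc2C(=O)/C=C/c2ccc(Cl)cc2Cl)cc1`: 8.34 ug/mL in this assay

Compound 2 stands beside compound 1 in this assay, the two numbers within the scatter of each other, as a 1.9-fold lower number from compound 1 to compound 2 (0.28 log units; within the scatter) shows. Compound 3, `Cc1ccc(S(=O)(=O)NC(=O)Nc2ccccc2C(=O)/C=C/c2cccnc2)cc1`, carries pyridin-3-yl in place of 2,4-dichlorophenyl on a double-bonded chain carbon bound to a double-bonded chain carbon. For the measured compounds named here, the one measured step swapped one ring of carbon only for another and stayed within the scatter, so no measured step bears directly on bringing in a ring with a hetero atom. A modest rise is nonetheless expected, a 1.8-fold higher number from compound 2 to compound 3 (0.25 log units; within the scatter). Compound 3 is expected to give 15 ug/mL, within 6 ug/mL to 40 ug/mL.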

Compound 3, concentration for half-maximal effect: 14.1 ug/mL
The estimate for compound 3 lay 1.1-fold (0.03 log units) above the measured number; the measured number falls inside the stated range.
By their numbers in this assay, from the lowest: compounds 2, 3 and 1 (each within the scatter of the next).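

Placing a ring with a hetero atom on a double-bonded chain carbon bound to a double-bonded chain carbon keeps the number in this assay within the scatter of both carbon-only rings (a 1.7-fold higher number from compound 2 to compound 3 (0.23 log units; within the scatter); a 1.1-fold lower number from compound 1 to compound 3 (0.05 log units; within the scatter)). At this position, pyridin-3-yl therefore cannot be told apart from 2,4-dichlorophenyl or 2,4-dimethoxyphenyl. No available evidence gives a reason for this result.

As far as these compounds go, whether pyridin-4-yl would read the same remains open. So does whether an amine or a carboxylic acid on this ring would take the number beyond the scatter.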